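Ethyl for methyl on an acylguanidine sulfone series

A few compounds are considered here, and "the series" means these few. Any claim that something is new, unique, unknown or untested is made for them only; others in the source may bear on it.

Measured compounds:
compound 1 `CCc1cc(Cl)c(S(C)(=O)=O)cc1C(=O)N=C(N)N` — 63 nM
compound 2 `CCc1cc(Br)c(S(C)(=O)=O)cc1C(=O)N=C(N)N` — 41 nM
compound 3 `COc1cc(C)c(C(=O)N=C(N)N)cc1S(C)(=O)=O` — 16 nM

In a functional assay for inhibition of sodium/hydrogen exchanger (Oryctolagus cuniculus) (a lower number here means a stronger inhibitor, a higher number a weaker inhibitor), compound 3 gives the lowest of the three numbers: compound 2 sits at 41 nM, a gap beyond the scatter, and compound 1 at 63 nM, further still. Compound 4 `CCc1cc(OC)c(S(C)(=O)=O)cc1C(=O)N=C(N)N` is not yet measured. It differs from compound 3 in one place: methyl in place of hydrogen on a saturated chain carbon bound to an aromatic carbon; cut one bond further out, the same difference reads methyl to ethyl.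

Going by the values given here, only one measured step exists, a 1.5-fold lower number from compound 1 to compound 2 (0.19 log units; within the scatter), and it concerns a halogen swap on the aromatic ring, not the chain. Among the compounds with values here, compounds 1 and 2 carry the ethyl chain that compound 4 will carry, but they differ from compound 3 in two places at once, so their values show only that ethyl-bearing analogues can reach this assay's range, not what the chain alone contributes. Within the data shown here, no measured step therefore bears directly on the change from compound 3 to compound 4. In this assay compound 4 is expected to give 16 nM, with a range from 6 nM to 40 nM. The step of no change at the digits printed from compound 3 to compound 4 (within the scatter) is accordingly expected to stay within the scatter, in either direction.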

Compound 4, half-maximal inhibitory concentration: 30 nM
For compound 4 the middle estimate is 1.9-fold (0.27 log units) below the measured one, and the stated range covers the measured number.
By their numbers in this assay, from the lowest: compounds 3, 4, 2 and 1 (each within the scatter of the next, the first and the last beyond it).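

Read directly for the first time in this assay the change of methyl to ethyl gives a 1.9-fold higher number from compound 3 to compound 4 (0.27 log units; within the scatter) and so shows that, with methoxy on the ring, this saturated chain carbon bound to an aromatic carbon can carry the added methyl without a step beyond the scatter. Going by these compounds alone, with the ethyl chain held fixed, methoxy in place of bromo gives a 1.4-fold lower number from compound 2 to compound 4 (0.14 log units; within the scatter) while methoxy in place of chloro gives a 2.1-fold lower number from compound 1 to compound 4 (0.32 log units; beyond the scatter) and is the only one of these steps to pass beyond the scatter, though it is modest. Methoxy on that aromatic carbon is thus separated from chloro but not from bromo, and the ethyl chain, earlier seen only alongside a halogen, now stands alongside methoxy as well.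

No measured evidence accounts for any of these steps. Going by these compounds, whether a propyl or longer chain, or a hydroxymethyl group, would be accepted on the same carbon remains open, as does whether the change of methyl to ethyl reads the same with chloro or bromo in place of methoxy.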